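Two Measured Analogues and One Carbonyl Substituent Changed

The source may hold more compounds than are shown below. What is called first, only, known or untested is meant among the compounds shown, and "the series" means these compounds.

Compound 1 `CCCOC(=O)C1=C(C)NC(=O)NC1c1ccsc1` gives 6% in an assay on membranes from HeLa cells for displacement of a labelled ligand from adenosine receptor A3 (Homo sapiens), read by scintillation counting, with a stated time of 180 min, tested at 1 uM; on this read-out higher numbers stand for more inhibition at the one concentration tested (going by the name of the read-out) and lower numbers for less inhibition. Compound 2 `CC1=C(C(=O)CC(C)C)C(c2ccsc2)NC(=O)N1` gives 14% in this assay.

Within the data shown here, compound 2 has the higher of the two numbers, the only neighbour being compound 1, where a number 8 percentage points higher from compound 1 to compound 2 (within the scatter). Compound 3 `CCNC(=O)C1=C(C)NC(=O)NC1c1ccsc1` differs from compound 2 by ethylamino in place of isobutyl on a carbonyl carbon. Among the measured compounds shown here, the one measured step, from propoxy to isobutyl on the same carbonyl carbon, stayed within the scatter, so no step beyond the scatter is expected here either, a number 5 percentage points lower from compound 2 to compound 3 (within the scatter). Compound 3 is expected to give about 9% in this assay, within 0% to 22%.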

Compound 3, a percentage reported as inhibition, at one concentration (the size of the read-out at that concentration, not a potency): 1%
The estimate for compound 3 lay 8 percentage points above the measured number; the range from low to high includes it.
By their numbers in this assay, from the lowest: compounds 3, 1 and 2 (each within the scatter of the next, the first and the last beyond it).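

Ethylamino in place of isobutyl on a carbonyl carbon gives a number 13 percentage points lower from compound 2 to compound 3 (beyond the scatter) in this assay and so shows that a change at this position can move the number beyond the scatter, which the earlier pair did not show. Ethylamino in place of propoxy gives a number 5 percentage points lower from compound 1 to compound 3 (within the scatter) and so the outcome of bringing in ethylamino depends on the group it replaces. No evidence is available that bears on this result.

On these data alone, whether a longer alkyl chain or a cyclic amine such as morpholine at this carbonyl carbon would raise the number remains open.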